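From 3-chlorophenyl to 4-bromophenyl on an amide nitrogen

The compounds below may be only part of what the source reports. "The series", "measured", "known", "first", "only" and "open" are said of these compounds alone.

In a functional assay on OVCAR-5 cells (Homo sapiens) for inhibition, read by CCK-8 assay, with a stated time of 72 h, tested at 1 uM (a lower number here means less inhibition of growth, a higher number more inhibition of growth at the concentration tested), compound 3 `CN(C)C(=O)c1cc2cnc(Nc3ccc(NC(=O)C4(C(=O)Nc5cccc(Cl)c5)CC4)cc3)nc2n1C1CCCC1` gives 15.5% and stands lowest of the three measured compounds. Above it lie compound 1 `CN(C)C(=O)c1cc2cnc(Nc3ccc(NC(=O)C4(C(=O)Nc5cccc(F)c5)CC4)cc3)nc2n1C1CCCC1` at 26.3% and compound 2 `CN(C)C(=O)c1cc2cnc(Nc3ccc(NC(=O)C4(C(=O)Nc5ccccc5F)CC4)cc3)nc2n1C1CCCC1` at 58% with the same shared core.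

Compound 4 `CN(C)C(=O)c1cc2cnc(Nc3ccc(NC(=O)C4(C(=O)Nc5ccc(Br)cc5)CC4)cc3)nc2n1C1CCCC1` differs from compound 3 in one place 4-bromophenyl in place of 3-chlorophenyl on an amide-type nitrogen with 4-bromophenyl in place of 3-chlorophenyl on an amide-type nitrogen. Among the measured compounds shown here, none of the measured compounds carries bromine, so the measured steps offer only partial guidance. Chloro in place of fluoro on an aromatic carbon gave a number 10.8 percentage points lower from compound 1 to compound 3 (beyond the scatter) as a modest step. 2-Fluorophenyl in place of 3-fluorophenyl gave a number 31.7 percentage points higher from compound 1 to compound 2 (beyond the scatter) as a large step, and 3-chlorophenyl in place of 2-fluorophenyl gave a number 42.5 percentage points lower from compound 2 to compound 3 (beyond the scatter) as another large one. Among these compounds, the step that changes only where the fluoro sits is the larger of the two single changes. Compound 4 changes both the halogen and its place on the ring, so a step of either sign is possible.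

With compound 3 already lowest at 15.5% a modest rise is the more likely outcome. The expected move is a number 10.5 percentage points higher from compound 3 to compound 4 (beyond the scatter) with wide uncertainty. The estimate for compound 4 is 26% with an expected range from 8% to 50% in this assay once it is measured.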

Compound 4, percent growth inhibition at one concentration: 13.7%
The estimate for compound 4 lay 12.3 percentage points above the measured number; the range from low to high includes it.
By their numbers in this assay, from the lowest: compounds 4 and 3 (each within the scatter of the next); then compound 1; then compound 2.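

In this assay, 4-bromophenyl in place of 3-chlorophenyl on the amide-type nitrogen gives a number 1.8 percentage points lower from compound 3 to compound 4 (within the scatter), so two rings that differ in both the halogen and its place on the ring read alike in this assay. Set against the two fluorinated rings, the same 4-bromophenyl gives a number 12.6 percentage points lower from compound 1 to compound 4 (beyond the scatter) and a number 44.3 percentage points lower from compound 2 to compound 4 (beyond the scatter), which leaves compound 2, with its 2-fluorophenyl, as the only one of the four compounds with a high number, while the new ring adds a second example that sits well below it. Nothing available here explains why these rings differ or why compound 3 and compound 4 read alike.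

Because the halogen and its place change together from compound 3 to compound 4, this pair cannot show whether each change does little or whether two larger effects cancel. On these data alone, it also stays open whether the high number of compound 2 is specific to fluoro, since an unsubstituted phenyl, a methoxy group or an amine on this ring would be needed to tell.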